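Benzofuranyl in place of ethynyl on the methoxy core

The compounds below may be only part of what the source reports. "The series", "measured", "known", "first", "only" and "open" are said of these compounds alone.

Measured compounds:
compound 1 `Nc1nc(N)c2c(-c3cc4ccccc4o3)cn([C@@H]3O[C@H](CO)[C@@H](O)[C@H]3O)c2n1`: > 20000 nM
compound 2 `C#Cc1cn([C@@H]2O[C@H](CO)[C@@H](O)[C@H]2O)c2ncnc(OC)c12`: > 20000 nM
compound 3 `C#Cc1cn([C@@H]2O[C@H](CO)[C@@H](O)[C@H]2O)c2ncnc(N(C)C)c12`: 90 nM

Compound 2 gives only a limit in a functional assay on CCRF-CEM cells (Homo sapiens), read by MTT assay, with a stated time of 72 h (a lower number here means a stronger inhibitor, a higher number a weaker inhibitor), > 20000 nM being the limit of the assay and not a number. Compound 1 likewise sits at a limit, > 20000 nM. Within the data shown here, compound 3 is the only compound with a number, 90 nM. Among the measured compounds shown here, the one measured step, an at least 220-fold lower number from compound 2 to compound 3 (2.34 log units; beyond the scatter), concerns a different place and does not bear on the change to compound 4 `COc1ncnc2c1c(-c1cc3ccccc3o1)cn2[C@@H]1O[C@H](CO)[C@@H](O)[C@H]1O`, which is 1-benzofuran-2-yl in place of ethynyl on an aromatic carbon. For the measured compounds named here, with the limit of > 20000 nM in this assay, at which 2 of the 3 values shown sit, no step informs the new group, so no move beyond the scatter is expected: the step of a number no higher from compound 2 to compound 4 (the limit leaves the size open) is the estimate. Compound 4 is therefore expected near 20000 nM, between 5000 nM and 60000 nM.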

Compound 4, half-maximal inhibitory concentration: 5370 nM
The estimate for compound 4 lay 3.7-fold (0.57 log units) above the measured number; low and high end bracket the measured number.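

In this assay, 1-benzofuran-2-yl in place of ethynyl on the methoxy core brings an at least 3.7-fold lower number from compound 2 to compound 4 (0.57 log units; beyond the scatter). This aromatic carbon therefore takes a group of two fused aromatic rings and gives a measurable number, which ethynyl on the same core did not. How large the step really is stays open, as its starting point is a limit of the assay and not a number: the limit of > 20000 nM in this assay, at which 2 of the 4 values shown sit.

The compounds shown leave open whether 1-benzofuran-2-yl would also serve on the dimethylamino core of compound 3. They also leave open whether a single ring at this carbon, such as phenyl or furan-2-yl, would give a similar step.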